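A few compounds are considered here, and "the series" means these few. Any claim that something is new, unique, unknown or untested is made for them only; others in the source may bear on it.

Measured so far:
compound 1 `COc1ccc2c(c1)C(n1ccccc1=O)=CC(C)(C)O2` — 6.55
compound 2 `CC1(C)C=C(n2ccccc2=O)c2cc(C(=O)c3cccs3)ccc2O1` — 6.4
compound 3 `Cc1ccccc1C(=O)c1ccc2c(c1)C(n1ccccc1=O)=CC(C)(C)O2` — 6.83

In a functional assay (aorta) with Rattus norvegicus as the target (on this read-out lower numbers stand for lower potency and higher numbers for higher potency (the scale is a negative logarithm)), compound 3 gives the highest of the three numbers. Its nearest neighbour is compound 1, a number 0.28 log units higher from compound 1 to compound 3 (within the scatter); the furthest is compound 2, a number 0.43 log units higher from compound 2 to compound 3 (beyond the scatter). Compound 3 is thus not separated from compound 1 beyond the scatter, and only modestly from compound 2.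

Compound 4 `CC1(C)C=C(n2ccccc2=O)c2cc(O)ccc2O1` is not yet measured in this assay. Its difference from compound 3:
hydroxy in place of (2-methylphenyl)carbonyl on an aromatic carbon
The whole (2-methylphenyl)carbonyl group is removed and a single hydroxy stands on the same aromatic carbon.

Among the compounds with values here, the step closest in kind is the one involving compound 1, which carries methoxy at that carbon: a number 0.28 log units higher from compound 1 to compound 3 (within the scatter) and a number 0.15 log units lower from compound 1 to compound 2 (within the scatter) both show that swapping methoxy for either carbonyl group moved the number only within the scatter. Within the data shown here, the single step beyond the scatter, a number 0.43 log units higher from compound 2 to compound 3 (beyond the scatter), concerns only the group on the carbonyl carbon and does not transfer to hydroxy. Hydroxy resembles methoxy more than either carbonyl group, so compound 4 is expected to land near compound 1, and the expected step is a number 0.33 log units lower from compound 3 to compound 4 (beyond the scatter), a small loss that may well sit within the scatter. Compound 4 is estimated at 6.5, with a range of 6 to 7.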

Compound 4, logarithm of the reciprocal of the active concentration, log(1/C): 5.44
For compound 4 the middle estimate is 1.06 log units above the measured one; measured number outside the range, below it.
By their numbers in this assay, from the lowest: compound 4; then compounds 2, 1 and 3 (each within the scatter of the next, the first and the last beyond it).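

In this assay, within the data shown here, this position had so far accepted methoxy and both carbonyl groups with little movement, the only step beyond the scatter lying between the two carbonyl groups, whereas hydroxy is the first group to fall clearly away from all three earlier compounds (a number 1.39 log units lower from compound 3 to compound 4 (beyond the scatter); a number 0.96 log units lower from compound 2 to compound 4 (beyond the scatter)). The most telling change is the smallest one, hydrogen in place of methyl on the oxygen on the aromatic ring (a number 1.11 log units lower from compound 1 to compound 4 (beyond the scatter)), so methoxy and hydroxy are not interchangeable here, and the size of the group alone does not order the series, since methoxy stands level with the far larger (2-methylphenyl)carbonyl group while hydroxy does not. No measurement at hand accounts for this drop.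

On these data alone, whether the loss belongs to hydroxy alone or extends to other small groups on the same aromatic carbon, such as an amine or a carboxylic acid, remains open. Also open, as far as these compounds go, is whether a longer ether chain, such as ethoxy, would stay with methoxy.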